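From 3-cyanopropyl to cycloheptyl on an aromatic nitrogen

The source may hold more compounds than are shown below. What is called first, only, known or untested is meant among the compounds shown, and "the series" means these compounds.

In a functional assay on HT-29 cells (Homo sapiens) for inhibition, read by luminescence and CellTiter-Glo, with a stated time of 24 h (on this read-out higher numbers stand for an effect only at larger amounts of compound and lower numbers for an effect already at smaller amounts), compound 3 (`CN1C(=S)[C@@H](NC(=O)c2nc(Cc3ccccc3)n(CCCC#N)n2)COc2ccccc21`) gives 2400 nM, within the scatter of compound 2 (`CC(C)Cn1nc(C(=O)N[C@H]2COc3ccccc3N(C)C2=S)nc1Cc1ccccc1`) at 1230 nM, whereas compound 1 (`CN1C(=S)[C@@H](NC(=O)c2nc(Cc3ccccc3)n(C)n2)COc2ccccc21`) gives 2.5 nM, far lower. Compound 4 (`CN1C(=S)[C@@H](NC(=O)c2nc(Cc3ccccc3)n(C3CCCCCC3)n2)COc2ccccc21`) carries cycloheptyl in place of 3-cyanopropyl on an aromatic nitrogen. Both measured replacements of the group on compound 1 raised the number sharply, with a 490-fold higher number from compound 1 to compound 2 (2.69 log units; beyond the scatter) and a 960-fold higher number from compound 1 to compound 3 (2.98 log units; beyond the scatter). Exchanging one replacement for the other gave a 2.0-fold higher number from compound 2 to compound 3 (0.29 log units; within the scatter). Cycloheptyl is a third replacement at this nitrogen, so no step beyond the scatter is expected in this assay, although only two such groups have been measured. The expected result is a 1.2-fold lower number from compound 3 to compound 4 (0.08 log units; within the scatter). Compound 4 is estimated at 2000 nM, with an expected range of 400 nM to 10000 nM.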

Compound 4, half-maximal effective concentration: 5530 nM
Beside the measured number, compound 4's estimate is 2.8-fold (0.44 log units) below it; measured number inside the range.
By their numbers in this assay, from the lowest: compound 1; then compounds 2 and 3 (each within the scatter of the next); then compound 4.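

In this assay, among the compounds shown here, cycloheptyl is the first ring at this aromatic nitrogen, and it separates from the open-chain groups, with a 2.3-fold higher number from compound 3 to compound 4 (0.36 log units; beyond the scatter) and a 4.5-fold higher number from compound 2 to compound 4 (0.65 log units; beyond the scatter), so the replacements for methyl are no longer all within the scatter of one another. Both steps are modest beside a 2200-fold higher number from compound 1 to compound 4 (3.34 log units; beyond the scatter): across these compounds, the large rise comes with leaving methyl for any of the three other groups, and the choice among those groups matters far less. Nothing available here explains this order. The compounds shown leave open whether ethyl or hydrogen on this nitrogen would keep a number close to that of compound 1. They also leave open whether an amine or a carboxylic acid at the end of the chain would behave like the nitrile of 3-cyanopropyl.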